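The compounds below may be only part of what the source reports. "The series", "measured", "known", "first", "only" and "open" are said of these compounds alone.

Compound 1 `CCn1cc(C(=O)O)c(=O)c2cc(F)c(N3CCN(C(=N)NS(=O)(=O)c4ccc(C)cc4)CC3)cc21` is a fluoroquinolone-type acid in which a piperazine carries a sulfonylguanidine capped with a 4-methylphenyl group. In a functional assay on HeLa cells (Homo sapiens) for antiproliferative activity, read by MTT assay, with a stated time of 72 h (on this read-out lower numbers stand for stronger inhibition and higher numbers for weaker inhibition), compound 1 gives 32 nM. Two close relatives have been measured alongside it. Compound 2 `Cc1ccc(S(=O)(=O)NC(=N)N2CCN(c3cc4c(cc3F)c(=O)c(C(=O)O)cn4C3CC3)CC2)cc1` gives 32 nM, and compound 3 `N=C(NS(=O)(=O)c1ccc(C(F)(F)F)cc1)N1CCN(c2cc3c(cc2F)c(=O)c(C(=O)O)cn3C2CC2)CC1` gives 32 nM, so compound 1 stands level with both and no one of the three can be called more or less potent than the others. The two recorded steps are no change at the digits printed from compound 1 to compound 2 (within the scatter) and no change at the digits printed from compound 2 to compound 3 (within the scatter).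

Compound 4 `CCn1cc(C(=O)O)c(=O)c2cc(F)c(N3CCN(C(=N)NS(=O)(=O)c4ccccc4C(F)(F)F)CC3)cc21` is now to be measured. It differs from compound 1 as follows: 2-(trifluoromethyl)phenyl in place of 4-methylphenyl on a sulfonyl sulfur. The step from compound 2 to compound 3 bears on this, since it also exchanges methyl for trifluoromethyl on the sulfonyl-bearing ring, though there the trifluoromethyl sits in the 4-position of the phenyl rather than the 2-position; that step produced no change beyond the scatter. The step from compound 1 to compound 2 shows that the ethyl group shared by compound 1 and compound 4 behaves like the cyclopropyl of compounds 2 and 3. Going by the values given here, no measured step addresses moving the substituent to the 2-position, so some uncertainty remains. On this basis compound 4 is expected to show essentially no change, a 1.1-fold higher number from compound 1 to compound 4 (0.05 log units; within the scatter), with an estimated value of 36 nM and a range from 14 nM to 95 nM.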

Compound 4, half-maximal inhibitory concentration: 32 nM
Compound 4: the middle estimate sits 1.1-fold (0.05 log units) above what was measured; low and high end bracket the measured number.
By their numbers in this assay, from the lowest: compounds 1, 2, 3 and 4 (each within the scatter of the next).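

In this assay, putting 2-(trifluoromethyl)phenyl in place of 4-methylphenyl on the sulfonyl sulfur gives no change at the digits printed from compound 1 to compound 4 (within the scatter). The earlier step at this aryl group, no change at the digits printed from compound 2 to compound 3 (within the scatter), kept the substituent in the 4-position, so compound 4 adds a case with a different substitution position and a larger group, 10 heavy atoms against 7, and the value still shows no separation from compound 1. Nothing available explains why this exchange leaves the value unmoved.

The compounds shown all carry a substituted phenyl ring on the sulfonyl sulfur, so it remains open whether an amine or a carboxylic acid on that ring, or a simple methyl in place of the whole ring, would shift the value. No compound shown pairs 2-(trifluoromethyl)phenyl with the cyclopropyl of compounds 2 and 3.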